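The compounds below may be only part of what the source reports. "The series", "measured", "known", "first", "only" and "open" are said of these compounds alone.

Measured in a physicochemical assay for solubility, using the shake flask method, in simulated intestinal fluid, measured as kinetic solubility, with a stated time of 2 h, at 25 degrees C, at pH 6.5; on this read-out lower numbers stand for lower solubility and higher numbers for higher solubility:
- Compound 1 `Cc1nc(C#N)c(N)c2c1C(=O)N(Cc1ccccc1)C2=O`: < 5000 nM
- Compound 2 `CCCOC(=O)c1nc(C)c2c(c1N)C(=O)N(Cc1ccccc1)C2=O`: < 5000 nM
- Compound 3 `Cc1nc(C(N)=O)c(N)c2c1C(=O)N(Cc1ccccc1)C2=O`: < 5000 nM

Each of these three entries is a limit of the assay and not a number. For the measured compounds named here, the series so far offers only (the limit of < 5000 nM in this assay, at which 3 of the 3 values shown sit).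

Compound 3 stands at < 5000 nM, which is a limit. Its exact place in the series therefore cannot be read.

Compound 4 `CNC(=O)c1nc(C)c2c(c1N)C(=O)N(Cc1ccccc1)C2=O` differs from compound 3 by methyl in place of hydrogen on an amide-type nitrogen. The same difference reads as carbamoyl to methylcarbamoyl.

Going by the values given here, three measured steps bear on this change, though none of them is the change itself. They are a step that the two limits leave unreadable from compound 1 to compound 3, a step that the two limits leave unreadable from compound 2 to compound 3 and a step that the two limits leave unreadable from compound 1 to compound 2. None has a readable size, so they give no measured basis for a shift in either direction.

In this assay, no step beyond the scatter is expected, and the estimated change is a step that the limit leaves unreadable from compound 3 to compound 4. Another limit is the most likely report for the next measurement.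

For compound 4 the expected value is 2500 nM, with an estimated range of 600 nM to 5000 nM.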

Compound 4, solubility: 41000 nM
Estimate against measurement, compound 4: 16-fold (1.21 log units) below, outside the stated range (above it).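

In this assay, for the compounds shown here, methyl in place of hydrogen on the amide-type nitrogen gives an at least 8.2-fold higher number from compound 3 to compound 4 (0.91 log units; beyond the scatter) as the first readable step at this position, so the carbamoyl group does not mark the end of what this place can show. Methylamino in place of propoxy on the carbonyl carbon gives an at least 8.2-fold higher number from compound 2 to compound 4 (0.91 log units; beyond the scatter) and methylcarbamoyl in place of cyano on the aromatic carbon gives an at least 8.2-fold higher number from compound 1 to compound 4 (0.91 log units; beyond the scatter), so all three readable steps run in the same direction and all end at the one compound reported as a number and not as a limit. The steps among compound 1, compound 2 and compound 3 cannot be read, and each step to compound 4 gives only a minimum size, as the other end of each is a limit: the limit of < 5000 nM in this assay, at which 3 of the 4 values shown sit.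

Going by these compounds, the full size of the methyl step stays open, and so does whether it holds for other compounds. Also open, on these data alone, is how the read-out responds to a longer chain such as ethyl or propyl on the same nitrogen, to a second methyl there, or to a carboxylic acid in place of the amide.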